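The compounds below may be only part of what the source reports. "The series", "measured", "known", "first", "only" and "open" are said of these compounds alone.

Measured so far in an assay on isolated protein for inhibition of phosphatidylinositol 4,5-bisphosphate 3-kinase catalytic subunit beta isoform (Homo sapiens); a lower number here means a stronger inhibitor, a higher number a weaker inhibitor:
compound 1 `CCN(CC)S(=O)(=O)c1cncc(-c2ccn3nc(N)nc3c2)c1` gives 25100000 nM
compound 2 `CCCNS(=O)(=O)c1cncc(-c2ccn3nc(N)nc3c2)c1` gives 31600000 nM
compound 3 `CS(=O)(=O)c1cncc(-c2ccn3nc(N)nc3c2)c1` gives 39800000 nM

Of the three numbers, that of compound 2 is the middle one, yet nothing separates it from its neighbours: a 1.3-fold higher number from compound 1 to compound 2 (0.10 log units; within the scatter) and a 1.3-fold higher number from compound 2 to compound 3 (0.10 log units; within the scatter) both lie within the scatter, as does a 1.6-fold higher number from compound 1 to compound 3 (0.20 log units; within the scatter). The next compound, compound 4 `Nc1nc2cc(-c3cncc(S(N)(=O)=O)c3)ccn2n1`, differs from compound 2 by hydrogen in place of propyl on a sulfonamide nitrogen. Every measured exchange on the sulfonyl sulfur left the number where it was, so the step from compound 2 to compound 4 is expected to be of the same kind, a 1.1-fold higher number from compound 2 to compound 4 (0.04 log units; within the scatter), none beyond the scatter in this assay. Compound 4 is therefore estimated at 35000000 nM, with a range from 15000000 nM to 80000000 nM.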

Compound 4, half-maximal inhibitory concentration: 39800000 nM
Beside the measured number, compound 4's estimate is 1.1-fold (0.06 log units) below it; the range from low to high includes it.
By their numbers in this assay, from the lowest: compounds 1, 2, 3 and 4 (each within the scatter of the next).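

In this assay, the series now reaches an unsubstituted sulfonamide nitrogen, and this exchange too stays within the scatter: a 1.3-fold higher number from compound 2 to compound 4 (0.10 log units; within the scatter), no change at the digits printed from compound 3 to compound 4 (within the scatter) and a 1.6-fold higher number from compound 1 to compound 4 (0.20 log units; within the scatter). Diethylamino, propylamino, methyl and amino on the sulfonyl sulfur therefore read alike at this position, whether the nitrogen carries two alkyl groups, one or none. No supporting data bear on this flat reading. Still open, going by these compounds, is whether a longer chain ending in an amine or a carboxylic acid on the sulfonyl sulfur would move the number beyond the scatter. Also open, on these data alone, is whether any exchange on the shared core would do so.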